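Swapping the aryl group on a thiosemicarbazone tail

The source may report more compounds than this note shows. Statements on the series, on what has been measured and on what is new or still open speak of the compounds shown alone.

Compounds measured so far in a functional assay on NCI-H460 cells (Homo sapiens) for cytotoxicity, read by sulforhodamine B assay; on this read-out lower numbers stand for stronger inhibition of growth and higher numbers for weaker inhibition of growth:
- compound 1, `CC1=CC[C@@H]([C@@](C)(O)CCCC(C)(C)NC=S)CC1`, 9250 nM
- compound 2, `COc1ccc(/C=N\NC(=S)NC(C)(C)CCC[C@](C)(O)[C@@H]2CC=C(C)CC2)cc1`, 5100 nM
- compound 3, `CC1=CC[C@@H]([C@@](C)(O)CCCC(C)(C)NC(=S)N/N=C\c2ccc(O)cc2)CC1`, 1460 nM

Among these three, compound 2 gives the second highest number; compound 1 lies within the scatter of it, while compound 3 sits well apart. Compound 4, `CC1=CC[C@@H]([C@@](C)(O)CCCC(C)(C)NC(=S)N/N=C\c2ccccc2[N+](=O)[O-])CC1`, is not yet measured. It differs from compound 2 by 2-nitrophenyl in place of 4-methoxyphenyl on a carbon with a double bond to nitrogen. Going by the values given here, only one measured step touches this part of the molecule: a 3.5-fold lower number from compound 2 to compound 3 (0.54 log units; beyond the scatter). Among the compounds with values here, that step shows that changing the aryl group can shift this assay modestly, but no measured compound carries a nitro group, so the direction for compound 4 is uncertain. Compound 4 is therefore expected to land near compound 2, with an estimated step of a 1.3-fold lower number from compound 2 to compound 4 (0.11 log units; within the scatter). The estimate for compound 4 is 4000 nM, within 1500 nM to 11000 nM.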

Compound 4, concentration for 50% growth inhibition: 20600 nM
The estimate for compound 4 lay 5.2-fold (0.71 log units) below the measured number; the whole stated range lies below it.
By their numbers in this assay, from the lowest: compound 3; then compounds 2 and 1 (each within the scatter of the next); then compound 4.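

In this assay, the aryl group on this carbon can raise the number as well as lower it: 2-nitrophenyl in place of 4-methoxyphenyl gives a 4.0-fold higher number from compound 2 to compound 4 (0.61 log units; beyond the scatter). Set against 4-hydroxyphenyl, the same group gives a 14-fold higher number from compound 3 to compound 4 (1.15 log units; beyond the scatter), so changes at this one position alone span a large range of growth inhibition. Nothing available explains this difference. The compounds shown cannot separate the effect of the nitro group from that of its place on the ring. From the compounds shown here alone, how a plain phenyl group or an aminophenyl group would behave here also remains open.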